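The compounds below may be only part of what the source reports. "The series", "measured", "known", "first", "only" and "open" are said of these compounds alone.

In a functional assay on the whole organism (strain Wister albino) for inhibition, with Rattus norvegicus as the target, read by paw edema, with stated times of 1 h and 3 h, at a dose of 50 mg/kg by the intraperitoneal route (a higher number here means more inhibition at the dose given (going by the name of the read-out), a lower number less inhibition), compound 1 `Cc1ccc([C@@H]2CN(C)[C@]3(C(=O)Nc4ccccc43)[C@]23Cc2ccccc2C3=O)cc1` gives 27.4%. Compound 2 `CN1C(=O)[C@@]2(c3ccccc31)N(C)C[C@@H](c1ccc(F)cc1)[C@@]21Cc2ccccc2C1=O` gives 26.9% in this assay.

Compound 2 stands lowest of these two numbers, and its nearest neighbour is compound 1, whose number is higher by an amount within the scatter. Compound 3 `Cc1ccc([C@@H]2CN(C)[C@]3(C(=O)N(C)c4ccccc43)[C@]23Cc2ccccc2C3=O)cc1` differs from compound 2 by methyl in place of fluoro on an aromatic carbon. Going by the values given here, no measured pair shows this change on its own; the two measured values, though, lie within the scatter of each other. The expected step from compound 2 to compound 3 in this assay is a number 0.1 percentage points higher from compound 2 to compound 3 (within the scatter), none beyond the scatter. Compound 3 is estimated at 27%, with a range from 18% to 36%.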

Compound 3, a percentage reported as inhibition, in the whole organism at one dose (the size of the read-out at that dose, not a potency): 6.4%
The estimate for compound 3 lay 20.6 percentage points above the measured number; measured number outside the range, below it.
By their numbers in this assay, from the lowest: compound 3; then compounds 2 and 1 (each within the scatter of the next).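

Putting methyl in place of fluoro on the aromatic carbon gives a number 20.5 percentage points lower from compound 2 to compound 3 (beyond the scatter), and putting methyl in place of hydrogen on the amide-type nitrogen gives a number 21 percentage points lower from compound 1 to compound 3 (beyond the scatter) in this assay. The low number thus appears only in compound 3, which carries both methyl groups, whereas compound 1 and compound 2, each carrying one, lie within the scatter of each other. Nothing available explains this drop. The compounds shown leave open how the 4-fluorophenyl group behaves alongside the amide hydrogen, and whether chloro or methoxy on that aromatic carbon, or an ethyl chain on that nitrogen, would act like methyl.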